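A few compounds are considered here, and "the series" means these few. Any claim that something is new, unique, unknown or untested is made for them only; others in the source may bear on it.

Compound 3 (`Cc1c(Cc2c(F)cccc2F)nc(N2CCCCC2)[nH]c1=O`) is the reference point in an ADME assay on MT4 cells (Homo sapiens) for cytotoxicity, read by MTT assay, with a stated time of 4 days (a lower number here means that less compound is tolerated, a higher number that more compound is tolerated), where it gives > 78000 nM, which is a limit and not a number. Compound 1 (`CCCN(C)c1nc(Cc2c(F)cccc2F)c(C)c(=O)[nH]1`) gives > 81000 nM, also a limit. Compound 2 (`Cc1c(Cc2c(F)cccc2F)nc(N(C)C2CCCCC2)[nH]c1=O`) gives > 72000 nM, again a limit. Compound 3 therefore has no exact place in the series, and neither of the other two values gives it one.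

The move to compound 4 (`Cc1c(Cc2c(F)cccc2F)nc(N2CCCC(C)C2)[nH]c1=O`) is methyl in place of hydrogen on a saturated ring carbon, turning piperidin-1-yl into 3-methylpiperidin-1-yl. The nearest measured changes are on the same amino group: a step that the two limits leave unreadable from compound 1 to compound 2, a step that the two limits leave unreadable from compound 1 to compound 3 and a step that the two limits leave unreadable from compound 2 to compound 3. None of these has a readable size, so they set no direction. All three compounds do end in limits in this assay, so no step beyond the scatter is expected for this small addition, and a further limit is the likely report. The expected change is an at least 1.0-fold lower number from compound 3 to compound 4 (0.01 log units; that floor lies within the scatter). For compound 4 the estimate is 75000 nM, with an expected range from 35000 nM to 90000 nM.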

Compound 4, half-maximal cytotoxic concentration: > 75000 nM
Compound 4 ended at the assay's limit; the forecaster's own chance of this, stated with the estimate: 80%; the middle value lies on the limit itself.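

In this assay compound 4 gives > 75000 nM, which is a limit and not a number. Its steps from compound 1, compound 2 and compound 3 cannot be read, since all four values are limits. The compounds shown leave open whether any of these amino groups on the shared core changes the half-maximal cytotoxic concentration.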